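Compound 1 to compound 4: a methoxy step

The source may hold more compounds than are shown below. What is called first, only, known or untested is meant among the compounds shown, and "the series" means these compounds.

In an ADME assay on THP-1 cells (Homo sapiens) for cytotoxicity, read by flow cytometry and propidium iodide staining, with a stated time of 72 h (on this read-out lower numbers stand for stronger inhibition and higher numbers for weaker inhibition), compound 1 (`CC(=O)Nc1ccc2oc(-c3cccc(F)c3)cc(=O)c2c1`) gives > 125000 nM as a limit of the assay, not a number. Compound 3 (`Nc1ccc2oc(-c3cccc(F)c3)cc(=O)c2c1`) gives > 125000 nM as a limit too. Going by the values given here, compound 2 (`CC(=O)Nc1ccc2oc(-c3cccc(C(F)(F)F)c3)cc(=O)c2c1`) gives 50000 nM as the only actual number so far. Trifluoromethyl in place of fluoro gave an at least 2.5-fold lower number from compound 1 to compound 2 (0.39 log units; beyond the scatter) as the one readable step. Hydrogen in place of acetyl gave a step that the two limits leave unreadable from compound 1 to compound 3 with no size to read. Compound 4 (`COc1c(-c2cccc(F)c2)oc2ccc(NC(C)=O)cc2c1=O`) carries methoxy in place of hydrogen on an aromatic carbon at a carbon that neither measured step changed. The series still stands largely at the limit of > 125000 nM in this assay, at which 2 of the 3 values shown sit, so only a small move to a lower number is expected in this assay and none may be readable. The estimated change is an at least 1.2-fold lower number from compound 1 to compound 4 (0.09 log units; that floor lies within the scatter) in size. For compound 4 the expected value is 100000 nM within an estimated range of 40000 nM to 250000 nM and a repeat of the limit is quite likely.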

Compound 4, half-maximal inhibitory concentration: > 125000 nM
Compound 4 was reported as a limit; the forecaster's own chance of this, stated with the estimate: 60%; middle value at least 1.2-fold (0.09 log units) from the limit.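

In this assay compound 4 gives > 125000 nM, a limit and not a number, and with compound 1 also at a limit, no step can be read. From the compounds shown here alone, whether methoxy in place of hydrogen changes the read-out at all stays open.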